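A few compounds are considered here, and "the series" means these few. Any claim that something is new, unique, unknown or untested is made for them only; others in the source may bear on it.

Of the compounds shown here, three built on the same core have so far been measured in a functional assay on HCT-116 cells (Homo sapiens) for antiproliferative activity, read by MTT assay, with a stated time of 72 h; on this read-out lower numbers stand for stronger inhibition and higher numbers for weaker inhibition. Compound 1 `Cc1ccccc1NC1=C/C(=N/NC(N)=S)C(=O)N=C1Nc1ccccc1C` gives 1520 nM, the lowest of the three numbers. Compound 3 `NC(=S)N/N=C1/C=C(Nc2ccc(F)cc2)C(Nc2ccc(F)cc2)=NC1=O` gives 3720 nM, a number that stands beyond the scatter above that of compound 1. Compound 2 `COc1ccc(NC2=C/C(=N/NC(N)=S)C(=O)N=C2Nc2ccc(OC)cc2)cc1` gives 22400 nM, the highest of the three and far beyond the scatter from compound 1. Compound 4 `Cc1ccccc1NC1=C/C(=N/N=C(\N)SCc2ccccc2)C(=O)N=C1Nc1ccccc1C` has not yet been measured. It differs from compound 1 in one place: a group of 11 heavy atoms (8 carbon, 2 nitrogen, 1 sulfur; one six-membered aromatic ring of carbon only) in place of a group of 4 heavy atoms (1 carbon, 2 nitrogen, 1 sulfur; no ring), on a double-bonded nitrogen. For the measured compounds named here, no pair of measured compounds shows what a change of this kind does to the read-out, so the direction of the step has to be guessed from compound 1 alone. In this assay the expected step of a 1.3-fold higher number from compound 1 to compound 4 (0.12 log units; within the scatter) is small and may well fall within the scatter, with no clear lean to either side. Compound 4 is therefore estimated at 2000 nM, with a range from 500 nM to 8000 nM.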

Compound 4, half-maximal inhibitory concentration: 13800 nM
For compound 4 the middle estimate is 6.9-fold (0.84 log units) below the measured one; the whole stated range lies below it.
By their numbers in this assay, from the lowest: compound 1; then compound 3; then compounds 4 and 2 (each within the scatter of the next).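

In this assay, for the compounds shown here, this is the first change at a single place that can be read: on the double-bonded nitrogen, a group of 11 heavy atoms with a six-membered aromatic ring of carbon only, in place of a group of 4 heavy atoms with no ring, gives a clear loss of inhibition (a 9.1-fold higher number from compound 1 to compound 4 (0.96 log units; beyond the scatter)). The read-out therefore responds to what sits at this place, even with the rest of compound 1 left untouched, and this larger group is not a neutral swap there. Nothing measured here speaks to why the number rises. The size of the group, its ring and its hydrogen-bond counts all change together in this one step, so a group ending in a methyl or a carboxylic acid instead of the aromatic ring would be needed to tell them apart. From the compounds shown here alone, whether the same change moves the number similarly on compound 2 or compound 3 also stays open.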